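The source may hold more compounds than are shown below. What is called first, only, known or untested is meant among the compounds shown, and "the series" means these compounds.

Of the compounds shown here, three built on one shared core have so far been tested in an ADME assay on HeLa Rh cells (Homo sapiens) for cytotoxicity, read by microscopy; on this read-out lower numbers stand for higher toxicity in this test and higher numbers for lower toxicity in this test. Compound 1 `COc1cc(CC(O)c2ccc(-c3ccc([N+](=O)[O-])cc3)cc2)c([N+](=O)[O-])cc1OC` gives 21000 nM, compound 2 `COc1cc(CC(O)c2ccc(-c3ccc(C)cc3)cc2)c([N+](=O)[O-])cc1OC` gives 4700 nM, and compound 3 `COc1cc(CC(O)c2ccc(-c3cccc(C#N)c3)cc2)c([N+](=O)[O-])cc1OC` gives 5200 nM. Compound 3 therefore stands level with compound 2, the step being a 1.1-fold higher number from compound 2 to compound 3 (0.04 log units; within the scatter). Compound 1 sits apart from both, with a 4.0-fold lower number from compound 1 to compound 3 (0.61 log units; beyond the scatter) and a 4.5-fold lower number from compound 1 to compound 2 (0.65 log units; beyond the scatter).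

Compound 4 `COc1cc(CC(O)c2ccc(-c3ccccc3F)cc2)c([N+](=O)[O-])cc1OC` keeps the core but carries 2-fluorophenyl in place of 3-cyanophenyl on an aromatic carbon. Within the data shown here, no measured step makes this exact exchange. The closest evidence is the exchange of 4-methylphenyl for 3-cyanophenyl, a 1.1-fold higher number from compound 2 to compound 3 (0.04 log units; within the scatter), where swapping one substituted phenyl for another left no difference beyond the scatter. The two larger steps both remove the 4-nitrophenyl group of compound 1, a group that compound 3 and compound 4 both lack, so they offer little guidance here. With so few compounds, this is thin support, and a surprise remains possible. No step beyond the scatter is expected in this assay, and the expected change is a 1.0-fold lower number from compound 3 to compound 4 (0.02 log units; within the scatter). For compound 4 the estimated value is 5000 nM, with an expected range from 2400 nM to 11000 nM.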

Compound 4, half-maximal cytotoxic concentration: 5000 nM
The estimate for compound 4 equals the measured number at the digits printed; measured number inside the range.
By their numbers in this assay, from the lowest: compounds 2, 4 and 3 (each within the scatter of the next); then compound 1.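

In this assay the exchange of 3-cyanophenyl for 2-fluorophenyl gives a 1.0-fold lower number from compound 3 to compound 4 (0.02 log units; within the scatter) and the exchange of 4-methylphenyl for 2-fluorophenyl gives a 1.1-fold higher number from compound 2 to compound 4 (0.03 log units; within the scatter) at this place on the ring, para to a large group. A third substituted phenyl, this one carrying fluorine, therefore joins the same level, and only compound 1 goes against this pattern, with a 4.2-fold lower number from compound 1 to compound 4 (0.62 log units; beyond the scatter) when its 4-nitrophenyl gives way to 2-fluorophenyl. No measurement shown here explains why these three groups give such similar numbers or why 4-nitrophenyl stands apart.

The compounds shown do not tell whether the high number of compound 1 depends on the nitro group itself or on where that group sits on the phenyl ring, as 4-nitrophenyl is the only nitrophenyl at this place. Also open, going by these compounds, is whether the shared level would hold for a phenyl ring carrying an amine or a carboxylic acid, or for a plain phenyl ring with no added group.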